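The compounds below may be only part of what the source reports. "The series", "measured", "known", "first", "only" and "open" are said of these compounds alone.

In a functional assay on SR cells (Homo sapiens) for inhibition, read by sulforhodamine B assay, with a stated time of 48 h (a lower number here means a stronger inhibitor of growth, a higher number a weaker inhibitor of growth), compound 3 `Nc1nn(C(=O)Nc2ccc(Cc3ccccc3)cc2)c2ccccc12` gives 15.3 nM, the lowest of the three numbers recorded. Compound 1 `O=C(Nc1ccccc1OC(F)(F)F)Nc1n[nH]c2ccccc12` gives 48.9 nM in this assay, and compound 2 `O=C(Nc1ccc(Cc2ccccc2)cc1)Nc1nn(C(=O)Nc2ccc(Cc3ccccc3)cc2)c2ccccc12` gives 16300 nM; both of these stand higher than compound 3 by more than the usual scatter. Compound 4 `CCCCOc1ccc(NC(=O)n2nc(N)c3ccccc32)cc1` differs from compound 3 in one place: butoxy in place of benzyl on an aromatic carbon. Among the measured compounds shown here, no pair of measured compounds shows a change of this kind, so the size of the step rests on judgment alone. A small change is expected, estimated as a 2.0-fold higher number from compound 3 to compound 4 (0.29 log units; within the scatter), toward a slightly higher number that need not exceed the scatter. Compound 4 is expected to give about 30 nM in this assay, within a range from 8 nM to 120 nM.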

Compound 4, concentration for 50% growth inhibition: 16000 nM
For compound 4 the middle estimate is 530-fold (2.73 log units) below the measured one; measured number above the stated range.
By their numbers in this assay, from the lowest: compound 3; then compound 1; then compounds 4 and 2 (each within the scatter of the next).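

Butoxy in place of benzyl gives a 1000-fold higher number from compound 3 to compound 4 (3.02 log units; beyond the scatter) in this assay, so the group at this position, para to a large group, can decide almost the whole of the growth inhibition, which the earlier compounds could not show. The change removes a six-membered aromatic ring of carbon only and adds a hydrogen-bond acceptor, and this single pair cannot separate the two. Nothing measured here accounts for the step. On these data alone, whether phenoxy, cyclohexylmethyl or a shorter chain such as methoxy would keep the low number of compound 3 remains open.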